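A few compounds are considered here, and "the series" means these few. Any claim that something is new, unique, unknown or untested is made for them only; others in the source may bear on it.

Measured compounds:
compound 1 `O=c1oc(-c2ccccc2)nn1CCCCN1CCN(C2CCCCC2)CC1` — 35 nM
compound 2 `O=c1oc(-c2ccccc2)nn1CCCCN1CCN(c2ccc(F)cc2)CC1` — 383 nM

Of the compounds shown here, two sharing a common core have been measured in an assay on cell membranes for displacement of a labelled ligand from Sigma non-opioid intracellular receptor 1 (Cavia porcellus), read by scintillation counting, with a stated time of 120 min; a higher number here means a weaker inhibitor, a lower number a stronger inhibitor. Compound 1 gives 35 nM in this assay, while compound 2 gives 383 nM. Compound 2 thus stands at the higher of the two numbers, with an 11-fold higher number from compound 1 to compound 2 (1.04 log units; beyond the scatter) separating it from compound 1.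

Compound 3 `O=c1oc(-c2ccccc2)nn1CCCCN1CCN(c2ccccn2)CC1` has not yet been measured. It differs from compound 2 by pyridin-2-yl in place of 4-fluorophenyl on an amine nitrogen in a ring. For the measured compounds named here, the only measured step, an 11-fold higher number from compound 1 to compound 2 (1.04 log units; beyond the scatter), bears on this change only indirectly: it shows that what sits on this ring nitrogen can move the number by a large amount, but it compares a cyclohexyl with a 4-fluorophenyl, not one aromatic ring with another. Going by the values given here, no measured pair isolates the swap of a 4-fluorophenyl for a pyridin-2-yl. The expectation for compound 3 is therefore uncertain; a modest rise in the number, beyond the scatter but far smaller than the measured step, is expected, so that a 2.1-fold higher number from compound 2 to compound 3 (0.32 log units; beyond the scatter) describes the anticipated change. Compound 3 is estimated at 800 nM, within a range from 200 nM to 3200 nM.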

Compound 3, inhibition constant: 944 nM
The estimate for compound 3 lay 1.2-fold (0.07 log units) below the measured number; the range from low to high includes it.
By their numbers in this assay, from the lowest: compound 1; then compound 2; then compound 3.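

In this assay, the swap on this amine nitrogen in a ring now compares one aromatic ring directly with another, and pyridin-2-yl in place of 4-fluorophenyl gives a 2.5-fold higher number from compound 2 to compound 3 (0.39 log units; beyond the scatter), a much smaller change than the one seen when an aromatic ring replaced the cyclohexyl. Measured against the cyclohexyl, pyridin-2-yl gives a 27-fold higher number from compound 1 to compound 3 (1.43 log units; beyond the scatter), so that among these three compounds both aromatic groups carry higher numbers than the saturated ring, and the exchange of one aromatic ring for the other still moves the number beyond the scatter. Nothing available explains either step, and no measurement here accounts for the difference between the two aromatic groups.

The swap from compound 2 to compound 3 removes the fluorine and brings a ring nitrogen at once, so the compounds shown cannot say which of the two changes the number; an unsubstituted phenyl on the same nitrogen would separate them. They also leave open whether the lower number of compound 1 extends to other saturated groups at this place, such as a cyclopentyl or a piperidin-4-yl, or to a benzyl, whose methylene carbon would stand between this nitrogen and an aromatic ring.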